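This account rests on a few compounds, and the source may have more. Where it says the series, first, only, none or still open, it means among the compounds named here.

Measured in an ADME assay (liver) for metabolic stability, with Liver microsome (Homo sapiens) as the target, read by LC-MS, using microsomes, with a stated time of 30 min, tested at 4 uM; on this read-out higher numbers stand for a more stable compound and lower numbers for a less stable compound:
compound 1 `CCN1CCN(c2nc(C)nc3c2nc(-c2ccccc2Cl)n3CCOC)CC1`: 31%
compound 2 `COCCn1c(-c2ccccc2Cl)nc2c(N3CCN4C(=O)CCC4C3)nc(C)nc21`: 32%
compound 3 `Cc1nc(N2CCN(C)CC2)c2nc(-c3ccccc3C(F)(F)F)n(C3CCOCC3)c2n1`: 24%

Compound 3 gives 24%, a number within the usual scatter of those of compound 1 and compound 2, so the three cannot be told apart. Compound 4 `Cc1nc(N2CCN(C)CC2)c2nc(-c3ccccc3C)n(C3CCOCC3)c2n1` differs from compound 3 in one place: methyl in place of trifluoromethyl on an aromatic carbon. This puts methyl in place of trifluoromethyl on an aromatic carbon, ortho to a large group. Among the measured compounds shown here, the only measured step, a number 1 percentage points higher from compound 1 to compound 2 (within the scatter), exchanges a different group and is small, so it offers no direct guide to this swap. With nothing pointing either way, no change beyond the scatter is expected, and the estimated move is a number 2 percentage points lower from compound 3 to compound 4 (within the scatter). Compound 4 is expected at 22%, with an estimated range of 10% to 36%.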

Compound 4, percent of the compound remaining: 18%
Compound 4: the middle estimate sits 4 percentage points above what was measured, within the range that was stated.
By their numbers in this assay, from the lowest: compounds 4, 3, 1 and 2 (each within the scatter of the next, the first and the last beyond it).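

Methyl in place of trifluoromethyl, ortho to a large group, gives a number 6 percentage points lower from compound 3 to compound 4 (within the scatter) in this assay. Among the compounds shown here, this step is the first direct look at this position, and on this read-out the two groups cannot be told apart, even though they differ in size and in their atoms. Nothing measured here bears on why the swap leaves the result within the scatter.

Still open, on these data alone, is how a nitrile or a methoxy group would read at this place on the same core. A longer chain, such as ethyl, poses the same question.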